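From hydroxy to methoxy on the weak compound 2

The source may report more compounds than this note shows. Statements on the series, on what has been measured and on what is new or still open speak of the compounds shown alone.

Measured so far in a functional assay on BMEC cells (Bos taurus) for antiproliferative activity; a lower number here means a stronger inhibitor, a higher number a weaker inhibitor:
Compound 1 `COc1cc(/C=C\Cc2cc(O)c3ccoc3c2)cc(OC)c1OC`: 49 nM
Compound 2 `COc1cc(/C=C/Cc2cc(O)c3ccoc3c2)cc(OC)c1OC`: 27700 nM
Compound 3 `COc1cc(/C=C/Cc2cc(O)c3cc(C)oc3c2)cc(OC)c1OC`: 12300 nM

Of these three, compound 2 has the highest number at 27700 nM and so is the weakest inhibitor of the set. Compound 4 `COc1cc(/C=C/Cc2cc(OC)c3ccoc3c2)cc(OC)c1OC` is still unmeasured. Compared with compound 2 it shows methyl in place of hydrogen on an oxygen on an aromatic ring and this is methyl in place of hydrogen on an oxygen on an aromatic ring, or hydroxy to methoxy. The large step of a 570-fold higher number from compound 1 to compound 2 (2.75 log units; beyond the scatter) goes with the fact that compounds 1 and 2 differ only in the configuration as drawn and so offers little guidance on this change. Closer is the modest step of a 2.3-fold lower number from compound 2 to compound 3 (0.35 log units; beyond the scatter) where methyl also replaces hydrogen, though on an aromatic carbon. With the place different, a step of that size or smaller, towards a lower number, is expected in this assay with only loose confidence. The expected change is a 1.7-fold lower number from compound 2 to compound 4 (0.24 log units; within the scatter). For compound 4 the estimated value is 16000 nM with an expected range from 5000 nM to 50000 nM.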

Compound 4, half-maximal inhibitory concentration: 75000 nM
Compound 4: middle estimate off by 4.7-fold (0.67 log units), on the low side, and the stated range ends below it.
By their numbers in this assay, from the lowest: compound 1; then compound 3; then compound 2; then compound 4.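

In this assay, hydroxy to methoxy on the aromatic ring gives a 2.7-fold higher number from compound 2 to compound 4 (0.43 log units; beyond the scatter), which shows that the free hydroxy of compound 2 cannot be capped with methyl without a measurable change. The direction is opposite to that of the other methyl step, a 2.3-fold lower number from compound 2 to compound 3 (0.35 log units; beyond the scatter), so among these compounds, adding a methyl has no single direction: it depends on where the methyl sits. Nothing in the information given accounts for this step or says what the hydroxy hydrogen contributes.

As far as these compounds go, the step is known only with the double bond drawn E, so whether methoxy would have a similar effect on the far stronger Z compound 1 remains open. Also open, from the compounds shown here alone, is how an amine or a longer ethoxy group in this place would compare with hydroxy and methoxy.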